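Replacing the tetrazolyl group of compound 2 with a carboxypyridinyl

A few compounds are considered here, and "the series" means these few. Any claim that something is new, unique, unknown or untested is made for them only; others in the source may bear on it.

Among the compounds with values here, compound 2 `CCC(C)(C)Cc1c[nH]c(CCc2ccc(-n3ncnn3)cc2)n1` gives 89 nM in a functional assay on HEK293 cells for agonist activity at Bombesin receptor subtype-3 (Homo sapiens), read by luminescence and calcium flux, with a stated time of 10 min (on this read-out higher numbers stand for an effect only at larger amounts of compound and lower numbers for an effect already at smaller amounts), and stands at the low end of the two numbers so far, within the scatter of its only neighbour. Compound 1 `CCC(C)(C)Cc1c[nH]c(CCc2ccc(-n3cccn3)cc2)n1` gives 106 nM in this assay, and the step of a 1.2-fold lower number from compound 1 to compound 2 (0.08 log units; within the scatter) is within the scatter. Compound 3 `CCC(C)(C)Cc1c[nH]c(CCc2ccc(-c3cccnc3C(=O)O)cc2)n1` carries the change (2-carboxypyridin-3-yl in place of 2H-tetrazol-2-yl on an aromatic carbon). Within the data shown here, the only measured step at this place, a 1.2-fold lower number from compound 1 to compound 2 (0.08 log units; within the scatter), was flat; no measured step covers a six-membered ring with a carboxylic acid. No step beyond the scatter is therefore expected, a 1.5-fold higher number from compound 2 to compound 3 (0.16 log units; within the scatter). Compound 3 is estimated at 130 nM, between 40 nM and 450 nM.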

Compound 3, half-maximal effective concentration: 95 nM
For compound 3 the middle estimate is 1.4-fold (0.14 log units) above the measured one, within the range that was stated.
By their numbers in this assay, from the lowest: compounds 2, 3 and 1 (each within the scatter of the next).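

At this place, on an aromatic carbon para to a large group, the flat picture in this assay extends from five-membered rings to a six-membered aromatic ring carrying a carboxylic acid: a 1.1-fold higher number from compound 2 to compound 3 (0.03 log units; within the scatter), and a 1.1-fold lower number from compound 1 to compound 3 (0.05 log units; within the scatter). 2-Carboxypyridin-3-yl brings 9 heavy atoms and 1 hydrogen-bond donor where 2H-tetrazol-2-yl has 5 heavy atoms and 0 hydrogen-bond donors, with no step beyond the scatter. No evidence on the reason is available. Open, going by these compounds, is whether a methyl ester in place of the carboxylic acid, or an amine or alkyl chain in place of the aromatic ring, stays equally flat.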